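Solubility notes: aryl ether variation on the shared core

The source may hold more compounds than are shown below. What is called first, only, known or untested is meant among the compounds shown, and "the series" means these compounds.

Compound 1 `COc1ccc(Oc2ccc3c(NCCCNCc4cccc(OC)c4O)ccnc3c2)cc1` and compound 2 `COc1cccc(CNCCCNc2ccnc3cc(Oc4cccc(N(C)C)c4)ccc23)c1O` share one core and differ only in the aryl group carried on an oxygen on an aromatic ring. In a physicochemical assay for solubility, with a stated time of 18 h, at pH 7.4 (a higher number here means a more soluble compound, a lower number a less soluble compound), compound 1 gives 14500 nM. In this assay compound 2 gives 14500 nM. Among the measured compounds shown here, the one step measured so far, no change at the digits printed from compound 1 to compound 2 (within the scatter), shows the two values level at the digits recorded, so compound 2 stands level with compound 1, and no order between them can be read.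

Compound 3 `COc1cccc(CNCCCNc2ccnc3cc(Oc4ccc(Cl)cc4)ccc23)c1O` has not yet been measured in this assay. It differs from compound 2 in the same place as the measured pair: 4-chlorophenyl in place of 3-(dimethylamino)phenyl on an oxygen on an aromatic ring. The step from compound 1 to compound 2 is the only one that bears on this change, and it was flat. Compound 3 carries a group with no hydrogen-bond acceptor where compound 2 carries one. For compound 3 the step is expected to be small and not clearly beyond the scatter, estimated as a 1.8-fold lower number from compound 2 to compound 3 (0.26 log units; within the scatter). For compound 3 the estimated solubility is 8000 nM, expected to fall between 2500 nM and 16000 nM.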

Compound 3, solubility: 14500 nM
Compound 3: middle estimate off by 1.8-fold (0.26 log units), on the low side; the range from low to high includes it.
By their numbers in this assay, from the lowest: compounds 1, 2 and 3 (each within the scatter of the next).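

In this assay, 4-chlorophenyl in place of 3-(dimethylamino)phenyl on an oxygen on an aromatic ring gives no change at the digits printed from compound 2 to compound 3 (within the scatter), so a group with 0 hydrogen-bond acceptors enters where one with 1 leaves and the read-out stays level. Chloro in place of methoxy on an aromatic carbon gives no change at the digits printed from compound 1 to compound 3 (within the scatter), which extends the flat reading to a second pair and leaves three aryl groups at this place with no order among them. No measurement is available that accounts for the three values coinciding at the digits printed.

The compounds shown leave open whether this level reading holds for groups of another kind on this oxygen, such as a carboxylic acid on the aromatic ring or a saturated amine such as piperidine in place of the aryl group. They also leave open how the read-out responds to changes elsewhere on the shared core, such as a longer chain in place of the present one.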